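A few compounds are considered here, and "the series" means these few. Any claim that something is new, unique, unknown or untested is made for them only; others in the source may bear on it.

Measured so far in a functional assay on NCI-H226 cells (Homo sapiens) for inhibition, read by MTT assay, with a stated time of 48 h, tested at 10 uM; a lower number here means less inhibition, a higher number more inhibition at the concentration tested (going by the name of the read-out):
- compound 1 `Cc1ccc(Nc2cc(NC(=O)Nc3c(Cl)cccc3Cl)ncn2)cc1C` gives 41.3%
- compound 2 `COc1cc(NC(=O)Nc2cc(Nc3ccc(F)c(Cl)c3)ncn2)cc(OC)c1` gives 36.7%
- compound 3 `COc1ccc(C(F)(F)F)cc1Nc1cc(NC(=O)Nc2c(Cl)cccc2Cl)ncn1` gives 60.1%

Compound 2 stands lowest of the three numbers in this assay. Its nearest neighbour is compound 1, whose value is within the scatter, so no order can be read between them; compound 3 sits beyond the scatter above it. No pair among these three differs in one place only, so no single step has been isolated.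

Compound 4 `COc1cc(NC(=O)Nc2cc(Nc3cc(Br)ccc3OC)ncn2)cc(OC)c1` is not yet measured. Relative to compound 2 the change is 5-bromo-2-methoxyphenyl in place of 3-chloro-4-fluorophenyl on a nitrogen on an aromatic ring. The shared core and the urea-linked dimethoxyphenyl are kept; only the aryl on the nitrogen changes.

Without an isolated step to lean on, the step of a number 5.3 percentage points higher from compound 2 to compound 4 (within the scatter) is expected to be small, in the direction of slightly more inhibition, and may well fall within the scatter. Compound 4 is estimated at 42%, with a range from 25% to 60%.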

Compound 4, a percentage reported as inhibition, at one concentration (the size of the read-out at that concentration, not a potency): 42.7%
The estimate for compound 4 lay 0.7 percentage points below the measured number; measured number inside the range.
By their numbers in this assay, from the lowest: compounds 2, 1 and 4 (each within the scatter of the next); then compound 3.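

In this assay, for the compounds shown here, this is the first isolated step at this position: 5-bromo-2-methoxyphenyl in place of 3-chloro-4-fluorophenyl on a nitrogen on an aromatic ring gives a number 6 percentage points higher from compound 2 to compound 4 (within the scatter) and does not separate the two compounds. The entering group has a hydrogen-bond acceptor that the leaving group lacks, yet with the urea-linked dimethoxyphenyl kept, no change can be read. No measurement bears on the reason for this result.

The bromine and methoxy enter together, so their separate contributions remain unresolved. Also open, on these data alone, is how a basic amine such as a piperazine, or a carboxylic acid, on this aryl group would read.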